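Compound 1 and compound 4: one group exchanged

The source may hold more compounds than are shown below. What is called first, only, known or untested is meant among the compounds shown, and "the series" means these compounds.

compound 1 `CN(c1ncco1)c1cnc(NCc2c(F)ccc3c2CCO3)n2cnnc12` gives 11 mL.min-1.g-1
compound 2 `CN(C)Cc1ccc(C(=O)Nc2cnc(NCc3c(F)ccc4c3CCO4)n3cnnc23)cc1` gives 13 mL.min-1.g-1
compound 3 `CN(C)C(=O)c1cc(-c2cnc(NCc3c(F)ccc4c3CCO4)c3cn[nH]c(=O)c23)n(C)n1` gives 21 mL.min-1.g-1

These three numbers all come from an ADME assay on microsomes from liver (Homo sapiens) for metabolic stability, read by LC-MS, using NADPH, with stated times of 5 min and 30 min, tested at 1 uM (on this read-out higher numbers stand for fast clearance and lower numbers for slow clearance), and compound 1 stands at 11 mL.min-1.g-1 with the numbers of compound 2 and compound 3 both inside the usual scatter of it, so no order can be read between compound 1 and either of them.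

Compound 4 `CN(c1ccn(C)n1)c1cnc(NCc2c(F)ccc3c2CCO3)n2cnnc12` has not yet been measured. It differs from compound 1 by 1-methyl-1H-pyrazol-3-yl in place of 1,3-oxazol-2-yl on a nitrogen on an aromatic ring, which turns methyl(1,3-oxazol-2-yl)amino into methyl(1-methyl-1H-pyrazol-3-yl)amino. Among the measured compounds shown here, no two measured compounds differ in one place only, so nothing measured shows this change directly. Compound 2 at 13 mL.min-1.g-1 and compound 3 at 21 mL.min-1.g-1 differ from compound 1 in more than one place and still stay within the scatter of it. On that ground, a step in this assay no larger than the scatter is expected, leaning slightly towards faster clearance, although the data give no firm direction. The estimated step is a 1.4-fold higher number from compound 1 to compound 4 (0.13 log units; within the scatter) and it is expected to remain within the scatter. For compound 4 the estimated value is 15 mL.min-1.g-1 with an expected range from 8 mL.min-1.g-1 to 30 mL.min-1.g-1 in this assay once it is measured.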

Compound 4, intrinsic clearance in microsomes: 11 mL.min-1.g-1
Compound 4: the middle estimate sits 1.4-fold (0.13 log units) above what was measured; measured number inside the range.
By their numbers in this assay, from the lowest: compounds 1, 4, 2 and 3 (each within the scatter of the next).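

In this assay, putting 1-methyl-1H-pyrazol-3-yl in place of 1,3-oxazol-2-yl on a nitrogen on an aromatic ring gives no change at the digits printed from compound 1 to compound 4 (within the scatter). Among the compounds shown here, this is the first direct reading at this position, as the earlier compounds differed from compound 1 in more than one place: one five-membered aromatic ring can be exchanged here for another, with the ring oxygen gone and a methyl added, and the clearance read-out stays within the usual scatter. No measurement shown explains this result or says where on these compounds clearance arises.

What the compounds shown leave open is how far this tolerance extends, since the single exchange covers only these two five-membered aromatic rings and says nothing about a six-membered ring such as pyridine, a saturated amine such as morpholine or an open alkyl chain on the same nitrogen. From the compounds shown here alone, it also remains open whether the methyl on that nitrogen can give way to a hydrogen or a longer chain without moving the read-out beyond the scatter.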